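From an aromatic to an open-chain amide substituent

The compounds below may be only part of what the source reports. "The series", "measured", "known", "first", "only" and "open" are said of these compounds alone.

In a functional assay on HOS cells (Homo sapiens) for inhibition, read by MTT assay, with a stated time of 72 h (on this read-out higher numbers stand for weaker inhibition and lower numbers for stronger inhibition), compound 1 `COc1ccccc1NC(=O)CCC(=O)OCCCCCCSc1ccc([N+](=O)[O-])c2nonc12` gives 2850 nM and compound 2 `COc1ccc(NC(=O)CCC(=O)OCCCCCCSc2ccc([N+](=O)[O-])c3nonc23)cc1` gives 1800 nM while compound 3 `COc1ccc(NC(=O)CCC(=O)OCCCCCCSc2ccc([N+](=O)[O-])c3nonc23)cc1OC` gives 1390 nM on the same scale. Compound 3 is level with compound 2 and lies beyond the scatter under compound 1. Compound 4 `CN(C)CCNC(=O)CCC(=O)OCCCCCCSc1ccc([N+](=O)[O-])c2nonc12` carries 2-(dimethylamino)ethyl in place of 3,4-dimethoxyphenyl on an amide-type nitrogen. The measured steps only change methoxy groups on the aromatic ring: a 1.6-fold lower number from compound 1 to compound 2 (0.20 log units; within the scatter) and a 1.3-fold lower number from compound 2 to compound 3 (0.11 log units; within the scatter) stay within the scatter and a 2.1-fold lower number from compound 1 to compound 3 (0.31 log units; beyond the scatter) is modest. None removes the ring, so they guide this change weakly and suggest no direction. No step beyond the scatter is expected in this assay here. The estimated step is a 1.1-fold higher number from compound 3 to compound 4 (0.03 log units; within the scatter) with wide uncertainty. Compound 4 is expected at 1500 nM (estimated range 500 nM to 4500 nM).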

Compound 4, half-maximal inhibitory concentration: 5020 nM
The estimate for compound 4 lay 3.3-fold (0.52 log units) below the measured number; the measured number lies above the stated range.
By their numbers in this assay, from the lowest: compounds 3, 2, 1 and 4 (each within the scatter of the next, the first and the last beyond it).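

Taking away the aromatic ring itself, which the methoxy changes never did, has a visible effect on this amide-type nitrogen in this assay: 2-(dimethylamino)ethyl gives a 3.6-fold higher number from compound 3 to compound 4 (0.56 log units; beyond the scatter) and a 2.8-fold higher number from compound 2 to compound 4 (0.45 log units; beyond the scatter). Against 2-methoxyphenyl, the same exchange gives a 1.8-fold higher number from compound 1 to compound 4 (0.25 log units; within the scatter), so its size depends on which aromatic group leaves. Nothing available explains these steps.

On these data alone, whether the ring's removal or the new amine matters more stays open; a plain hexyl chain on this nitrogen, or a dimethylamino group carried on a phenyl ring, could separate the two.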